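Trimming the sulfonamide chain of compound 2

The source may hold more compounds than are shown below. What is called first, only, known or untested is meant among the compounds shown, and "the series" means these compounds.

In an ADME assay on a cell-free system (plasma, Mus musculus) (on this read-out lower numbers stand for a smaller free fraction and higher numbers for a larger free fraction), compound 1 `CCCS(=O)(=O)c1cccc(C#Cc2cc(Cl)ccc2OCC(=O)O)c1` gives 0.024, compound 2 `COCCN(C)S(=O)(=O)c1ccc(C)c(C#Cc2cc(Cl)ccc2OCC(=O)O)c1` gives 0.007 and compound 3 `CCCS(=O)(=O)c1ccc(F)c(C#Cc2cc(Cl)ccc2OCC(=O)O)c1` gives 0.007. Compound 2 is therefore level with compound 3, and the two share the lowest number of the three.

The next compound is compound 4 `Cc1ccc(S(=O)(=O)N(C)C)cc1C#Cc1cc(Cl)ccc1OCC(=O)O`, which differs from compound 2 as follows: hydrogen in place of methoxymethyl on a saturated chain carbon bound to a sulfonamide nitrogen. In short, hydrogen stands in place of methoxymethyl on a saturated chain carbon bound to a sulfonamide nitrogen, turning 2-methoxyethyl into methyl.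

Within the data shown here, only one measured step changes a single place: a 3.4-fold lower number from compound 1 to compound 3 (0.54 log units; beyond the scatter), with fluoro in place of hydrogen on an aromatic carbon. Among the measured compounds shown here, that step lies beyond the scatter, but it sits at a different place, so it shows only that one small change can move this assay. For the measured compounds named here, no measured step touches the sulfonamide nitrogen chain, so no direction can be drawn from the data.

The expected result is a 1.1-fold higher number from compound 2 to compound 4 (0.06 log units; within the scatter), with no shift beyond the scatter. For compound 4 the estimated value is 0.008, with an expected range of 0.004 to 0.017.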

Compound 4, unbound fraction: 0.01
Compound 4: the middle estimate sits 1.3-fold (0.10 log units) below what was measured, within the range that was stated.
By their numbers in this assay, from the lowest: compounds 2, 3 and 4 (each within the scatter of the next); then compound 1.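

In this assay, among these compounds, the change from 2-methoxyethyl to methyl on the sulfonamide nitrogen gives a 1.4-fold higher number from compound 2 to compound 4 (0.15 log units; within the scatter) and is the first measured step at this place. At this position, the methoxymethyl part of the chain can therefore give way to hydrogen without a shift beyond the scatter, something the fluoro step at a different place could not show. No supporting data bear on this result, so the flat step stands as an observation without an explanation.

Still open, as far as these compounds go, is whether a longer chain on the sulfonamide nitrogen would leave the free fraction equally unchanged. Also open, from the compounds shown here alone, is whether a chain carrying an amine or a carboxylic acid would move this read-out beyond the scatter.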